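Replacing the Thiophene Arm of a Hydrazone with Naphthalene

A few compounds are considered here, and "the series" means these few. Any claim that something is new, unique, unknown or untested is made for them only; others in the source may bear on it.

Compound 1 `CCCSc1nc(N/N=C/c2cccs2)c2nnn(Cc3ccccc3)c2n1` gives > 64000 nM in a functional assay on MGC-803 cells (Homo sapiens) for antiproliferative activity, read by MTT assay, with a stated time of 72 h; on this read-out lower numbers stand for stronger inhibition and higher numbers for weaker inhibition; this is a limit of the assay rather than a number.
Compound 2 `CCCSc1nc(N/N=C(\C)c2ccc(Br)cc2)c2nnn(Cc3ccccc3)c2n1` gives 6020 nM in this assay.

Compound 1 thus stands at the limit of > 64000 nM in this assay, at which 1 of the 2 values shown sits, so only its limit is known. Compound 3 `CCCSc1nc(N/N=C/c2ccc3ccccc3c2)c2nnn(Cc3ccccc3)c2n1` differs from compound 1 by naphthalen-2-yl in place of thiophen-2-yl on a carbon with a double bond to nitrogen. Among the measured compounds shown here, the single measured step, an at least 10-fold lower number from compound 1 to compound 2 (1.02 log units; beyond the scatter), also alters the group in this place and reaches a measurable number. A step in the same direction is therefore expected, but its size is uncertain. Compound 3 is estimated at 25000 nM (range 5000 nM to 80000 nM), which means an expected step of an at least 2.5-fold lower number from compound 1 to compound 3 (0.40 log units; beyond the scatter).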

Compound 3, half-maximal inhibitory concentration: > 64000 nM
Compound 3: a limit, no number; the forecaster's own chance of this, stated with the estimate: 40%; middle value at least 2.5-fold (0.40 log units) away from the limit.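

Compound 1 and compound 3 both give a limit of the assay rather than a number, so no step between them can be read: the limit of > 64000 nM in this assay, at which 2 of the 3 values shown sit.

Going by these compounds, whether naphthalen-2-yl and thiophen-2-yl differ at all in their effect on these cells stays open.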